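Nitro to chloro on a shared core

The source may report more compounds than this note shows. Statements on the series, on what has been measured and on what is new or still open speak of the compounds shown alone.

Compound 1 `O=C(Nc1ccc(I)cc1)Nn1c(-c2ccccc2)nc2ccccc2c1=O` gives 60% in a functional assay on the whole organism (strain albino) with Mus musculus as the target, at a dose of 100 mg/kg by the intraperitoneal route; a lower number here means less inhibition, a higher number more inhibition at the dose given (going by the name of the read-out).
Compound 2 `CCc1ccc(NC(=O)Nn2c(-c3ccccc3)nc3ccccc3c2=O)cc1` gives 61% in this assay.
Compound 3 `O=C(Nc1ccc([N+](=O)[O-])cc1)Nn1c(-c2ccccc2)nc2ccccc2c1=O` gives 42% in this assay.

Compound 3 stands lowest of the three numbers in this assay: the change is a number 18 percentage points lower from compound 1 to compound 3 (beyond the scatter), and a number 19 percentage points lower from compound 2 to compound 3 (beyond the scatter), both beyond the scatter. The two compounds without nitro sit together, since a number 1 percentage points higher from compound 1 to compound 2 (within the scatter) lies within the scatter.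

Compound 4 `O=C(Nc1ccc(Cl)cc1)Nn1c(-c2ccccc2)nc2ccccc2c1=O` differs from compound 3 in one place: chloro in place of nitro on an aromatic carbon. Among the compounds with values here, the steps that bear on this are the two that lead into compound 3, each a modest drop when nitro enters in place of iodo or ethyl. The change to compound 4 runs the other way, with nitro leaving and a single chlorine entering; the nearest measured parallel is the step from compound 1 to compound 3 reversed. An upward step of modest size in this assay is therefore expected, roughly a number 15 percentage points higher from compound 3 to compound 4 (beyond the scatter). On this basis compound 4 is estimated at 57%, with a range from 45% to 68%.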

Compound 4, a percentage reported as inhibition, in the whole organism at one dose (the size of the read-out at that dose, not a potency): 55%
Beside the measured number, compound 4's estimate is 2 percentage points above it; the range from low to high includes it.
By their numbers in this assay, from the lowest: compound 3; then compounds 4, 1 and 2 (each within the scatter of the next).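

In this assay, the step of a number 13 percentage points higher from compound 3 to compound 4 (beyond the scatter) shows that the lower number at this position does not need iodo or ethyl to be lifted: a single chlorine in place of nitro on the aromatic carbon para to a large group does so as well. The steps of a number 6 percentage points lower from compound 2 to compound 4 (within the scatter) and a number 5 percentage points lower from compound 1 to compound 4 (within the scatter) place chloro with ethyl and iodo, and among the four groups shown on this carbon only nitro stands apart. No measurement offered here explains why nitro behaves differently from the other three.

The compounds shown leave open where an amine, a methoxy group or a carboxylic acid on this carbon would fall. They also leave open whether chloro in place of nitro gives a similar step at another place on this ring or on another core.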